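This account rests on a few compounds, and the source may have more. Where it says the series, first, only, none or still open, it means among the compounds named here.

Of the compounds shown here, three sharing one core have been tested in a functional assay on the whole organism (strain Sprague-Dawley) for inhibition, with Rattus norvegicus as the target, with a stated time of 10 min; on this read-out lower numbers stand for an effect already at smaller amounts and higher numbers for an effect only at larger amounts of compound. Compound 1 `O=C(O)c1cnc(-c2ccccc2Cl)[nH]c1=O`, carrying a chloro group, gives 5 mg/kg in this assay. Compound 3 `CC(C)Oc1ccccc1-c1ncc(C(=O)O)c(=O)[nH]1`, with an isopropoxy group in the same place, gives 0.8 mg/kg in this assay. For compound 2 `O=C(O)c1cnc(-c2ccccc2[N+](=O)[O-])[nH]c1=O`, which carries a nitro group, this assay reports only a limit, > 50 mg/kg, so its true position is not a number. Compound 2 thus stands highest of the three, since the step of an at least 10-fold higher number from compound 1 to compound 2 (1.00 log units; beyond the scatter) and the step of an at least 62-fold lower number from compound 2 to compound 3 (1.79 log units; beyond the scatter) both run beyond the scatter. The compound not yet measured is compound 4 `CCCCCOc1ccccc1-c1ncc(C(=O)O)c(=O)[nH]1`. Its change from compound 2 is pentyloxy in place of nitro on an aromatic carbon. The step that bears most on it is an at least 62-fold lower number from compound 2 to compound 3 (1.79 log units; beyond the scatter), where an alkoxy group likewise replaced the nitro group; the step of a 6.3-fold lower number from compound 1 to compound 3 (0.80 log units; beyond the scatter) shows the isopropoxy compound also more potent than the chloro compound. Pentyloxy, like isopropoxy, is an alkoxy group, so for compound 4 an expected step of an at least 33-fold lower number from compound 2 to compound 4 (1.52 log units; beyond the scatter) seems reasonable, toward a lower dose. Compound 4 is therefore expected to give about 1.5 mg/kg in this assay, between 0.4 mg/kg and 6 mg/kg.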

Compound 4, dose for 50% inhibition: 3 mg/kg
Compound 4: the middle estimate sits 2.0-fold (0.30 log units) below what was measured; the measured number falls inside the stated range.
By their numbers in this assay, from the lowest: compound 3; then compounds 4 and 1 (each within the scatter of the next). At a limit, above all of these: compound 2.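

A second alkoxy group on this aromatic carbon again outperforms nitro in this assay, giving an at least 16-fold lower number from compound 2 to compound 4 (1.22 log units; beyond the scatter), and that size is only a lower bound. Compound 2 has a limit rather than a number: the limit of > 50 mg/kg in this assay, at which 1 of the 4 values shown sits. What is new is that the alkyl part of the alkoxy group matters, since pentyl in place of isopropyl on the oxygen gives a 3.8-fold higher number from compound 3 to compound 4 (0.57 log units; beyond the scatter), while the pentyloxy and chloro compounds cannot be told apart, with a 1.7-fold lower number from compound 1 to compound 4 (0.22 log units; within the scatter).

The compounds shown leave open how the dose responds to other alkyl parts on this oxygen, such as a shorter ethyl chain or a cyclopentyl ring. They also leave open whether an amine on this aromatic carbon would behave like the alkoxy groups or like nitro.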